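The source may hold more compounds than are shown below. What is called first, only, known or untested is meant among the compounds shown, and "the series" means these compounds.

For the measured compounds named here, in a functional assay on HL-60 cells (Homo sapiens) for antiproliferative activity, read by MTT assay, with a stated time of 72 h (a higher number here means a weaker inhibitor, a lower number a stronger inhibitor), two compounds sharing one core have numbers so far. Compound 1 `COc1ccc(OCCCON2C(N)=NC(N)=NC23CCOCC3)cc1` gives 1670 nM, and compound 2 `Cc1ccc(OCCCON2C(N)=NC(N)=NC23CCOCC3)cc1` gives 2580 nM. Going by the values given here, compound 2 therefore stands level with compound 1, since the only measured step, a 1.5-fold higher number from compound 1 to compound 2 (0.19 log units; within the scatter), does not separate them.

Compound 3 `NC1=NC2(CCOCC2)N(OCCCOc2ccc(Br)cc2)C(N)=N1` has not been measured. It differs from compound 2 at one place: bromo in place of methyl on an aromatic carbon. Among the compounds with values here, no measured compound carries bromo, so the evidence is thin. Within the data shown here, the one step that bears on this change is the swap of one small group for another on an aromatic carbon, a 1.5-fold higher number from compound 1 to compound 2 (0.19 log units; within the scatter), and a similar swap is expected to stay as small. The estimated step is a 1.3-fold lower number from compound 2 to compound 3 (0.11 log units; within the scatter), so no shift beyond the scatter is expected. For compound 3 the expected value is 2000 nM, with an estimated range from 900 nM to 4500 nM.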

Compound 3, half-maximal inhibitory concentration: 310 nM
Compound 3: middle estimate off by 6.5-fold (0.81 log units), on the high side; the measured number lies below the stated range.
By their numbers in this assay, from the lowest: compound 3; then compounds 1 and 2 (each within the scatter of the next).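

The aromatic carbon para to a large group is not indifferent to what it carries: methyl and methoxy could not be separated there, yet in this assay bromo gives an 8.3-fold lower number from compound 2 to compound 3 (0.92 log units; beyond the scatter) and a 5.4-fold lower number from compound 1 to compound 3 (0.73 log units; beyond the scatter). Exchanging methyl for bromo swaps one heavy atom for one heavy atom, with no ring, net charge or hydrogen-bond donor or acceptor counted on either side, and still moves the number beyond the scatter. Nothing measured here explains why bromo stands apart from methyl and methoxy.

On these data alone, it remains open whether the lower number belongs to bromo alone or is shared by chloro, fluoro, trifluoromethyl or nitrile at this carbon. Also open, as far as these compounds go, is whether bromo would give a step of similar size on a different carbon of the same aromatic ring.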